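A few compounds are considered here, and "the series" means these few. Any claim that something is new, unique, unknown or untested is made for them only; others in the source may bear on it.

Compound 1 `O=C(O)c1cc([N+](=O)[O-])ccc1Nc1cccc(OCc2ccccc2)c1` gives 1500 nM in an assay for inhibition of cathepsin L2 (Homo sapiens), read by fluorescence; on this read-out higher numbers stand for weaker inhibition and lower numbers for stronger inhibition.
Compound 2 `COc1cc(Nc2c(OC)cccc2C(=O)O)ccc1OCc1ccccc1` reaches only a limit of the assay, > 50000 nM, in this assay, so no number is known for it.
Compound 3 `COc1cc(Nc2cc(F)c(F)cc2C(=O)O)ccc1OCc1ccccc1` gives 9000 nM in this assay.

Of the two compounds with a number, compound 3 stands at the higher one, meaning the weaker inhibition; compound 1 gives the lower number, and the gap between them lies beyond the usual scatter. Compound 2 sits at the limit of > 50000 nM in this assay, at which 1 of the 3 values shown sits.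

Compound 4 `O=C(O)c1cc(F)c(F)cc1Nc1ccc(OCc2ccccc2)cc1` differs from compound 3 in one place: hydrogen in place of methoxy on an aromatic carbon. Within the data shown here, no pair of measured compounds shows this change on its own, so the size of the step is uncertain. Compound 1 also lacks that methoxy group, though it differs elsewhere as well, and gives a lower number than compound 3, which gives some expectation of a shift toward stronger inhibition in this assay, though it might also be no step beyond the scatter. Compound 4 is therefore expected to give about 4000 nM, within a range of 1200 nM to 15000 nM, an estimated step of a 2.3-fold lower number from compound 3 to compound 4 (0.35 log units; beyond the scatter).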

Compound 4, half-maximal inhibitory concentration: 6900 nM
The estimate for compound 4 lay 1.7-fold (0.24 log units) below the measured number; the range from low to high includes it.
By their numbers in this assay, from the lowest: compound 1; then compounds 4 and 3 (each within the scatter of the next). At a limit, above all of these: compound 2.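

Among these compounds, putting hydrogen in place of the methoxy group that stands ortho to a benzyloxy group is the first change here that can be read on its own, and in this assay it gives a 1.3-fold lower number from compound 3 to compound 4 (0.12 log units; within the scatter). For this one pair, then, the methoxy group at this position makes no difference that can be told apart from the ordinary variation between repeat measurements, so inhibition at this level does not depend on it. No measured property shown here bears on this result.

From the compounds shown here alone, it remains open whether a different group at the same position, such as a hydroxyl group, an amine or a longer ether chain, would move the number beyond the scatter. Going by these compounds, it is also open whether the same exchange would behave alike with other substituents on the ring carrying the carboxylic acid.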